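Thiophene carboxamide series: amine nitrogen substituent swap

This account rests on a few compounds, and the source may have more. Where it says the series, first, only, none or still open, it means among the compounds named here.

Of the compounds shown here, three of the shared core have numbers so far. Compound 1 `NC(=O)c1c(NC(=O)c2ccccc2Cl)sc2c1CCN(Cc1ccc(Cl)cc1Cl)C2` gives 8010 nM in a functional assay on HL-60 cells (Homo sapiens) for antiproliferative activity, with a stated time of 24 h; on this read-out lower numbers stand for stronger inhibition and higher numbers for weaker inhibition. Compound 2 `NC(=O)c1c(NC(=O)c2ccc(C(F)(F)F)cc2)sc2c1CCN(Cc1ccc(Cl)cc1Cl)C2` gives 14900 nM in this assay, and compound 3 `NC(=O)c1c(NC(=O)c2cccc([N+](=O)[O-])c2)sc2c1CCN(Cc1ccc(Cl)cc1Cl)C2` gives 19800 nM in this assay. Compound 2 stands second highest of the three numbers: its nearest neighbour is compound 3, a gap within the scatter, and its furthest is compound 1, also within the scatter. Within the data shown here, the only step beyond the scatter is a 2.5-fold higher number from compound 1 to compound 3 (0.39 log units; beyond the scatter), a modest one; the step of a 1.9-fold higher number from compound 1 to compound 2 (0.27 log units; within the scatter) and the step of a 1.3-fold higher number from compound 2 to compound 3 (0.12 log units; within the scatter) both stay within the scatter.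

Compound 4 `NC(=O)c1c(NC(=O)c2ccc(C(F)(F)F)cc2)sc2c1CCN(C(=S)Nc1ccccc1Cl)C2` is not yet measured. It differs from compound 2 as follows: a group of 10 heavy atoms (7 carbon, 1 nitrogen, 1 sulfur, 1 chlorine; one six-membered aromatic ring of carbon only) in place of a group of 9 heavy atoms (7 carbon, 2 chlorine; one six-membered aromatic ring of carbon only), on an amine nitrogen in a ring. All three measured steps change the aryl group on the carbonyl carbon; none touches the substituent on the amine nitrogen in the ring. Among the measured compounds shown here, there is therefore no measured step that bears on this change, and no direction can be read from the data. In the absence of any bearing step, the expectation is simply that compound 4 stays near compound 2, whose value is 14900 nM, with a wide range. This is expected to amount to a 1.2-fold lower number from compound 2 to compound 4 (0.09 log units; within the scatter). For compound 4 the estimated value is 12000 nM, between 3000 nM and 50000 nM.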

Compound 4, half-maximal inhibitory concentration: 36100 nM
Compound 4: the middle estimate sits 3.0-fold (0.48 log units) below what was measured; the range from low to high includes it.
By their numbers in this assay, from the lowest: compounds 1, 2, 3 and 4 (each within the scatter of the next, the first and the last beyond it).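

The substituent on the amine nitrogen in the ring gets its first reading in this assay: with 4-(trifluoromethyl)phenyl held on the carbonyl carbon, the group of 10 heavy atoms in place of 2,4-dichlorobenzyl gives a 2.4-fold higher number from compound 2 to compound 4 (0.38 log units; beyond the scatter), toward weaker inhibition. Among these compounds, this position therefore responds to substitution, and the shift lies beyond the scatter, as does only one of the earlier steps on the aryl group on the carbonyl carbon. The change brings in a double bond outside aromatic rings, a hydrogen-bond donor and a hydrogen-bond acceptor all at once, and no supporting data separate their contributions or explain the shift.

Still open, on these data alone, is which part of the new group carries the step; a urea with oxygen in place of the sulfur, or an unsubstituted benzyl or a methyl on the same nitrogen, would begin to separate these parts. Also open, as far as these compounds go, is whether the step holds with 2-chlorophenyl or 3-nitrophenyl on the carbonyl carbon, since this nitrogen swap has been read with 4-(trifluoromethyl)phenyl alone.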